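The source may hold more compounds than are shown below. What is called first, only, known or untested is meant among the compounds shown, and "the series" means these compounds.

Of the compounds shown here, two of a shared core have been measured in an assay on isolated protein for inhibition of Amine oxidase [flavin-containing] A (Homo sapiens), read by fluorescence, with a stated time of 30 min; a lower number here means a stronger inhibitor, a higher number a weaker inhibitor. Compound 1 `CCN(CCCCCCn1sc2cc(OC)c(OC)cc2c1=O)Cc1ccccc1` gives 8200 nM. Compound 2 `COc1ccccc1CN(C)CCCCCCn1sc2cc(OC)c(OC)cc2c1=O` gives 19900 nM, the higher of the two numbers, and the gap to compound 1 lies beyond the usual scatter of this assay. Compound 3 `CCN(CCCCCCn1sc2cc(OC)c(OC)cc2c1=O)Cc1ccccc1OC` has not yet been measured. It differs from compound 2 in a single place: methyl in place of hydrogen on a saturated chain carbon bound to an amine nitrogen, a methyl in place of hydrogen on a saturated chain carbon bound to an amine nitrogen, which read one bond further out is methyl to ethyl. Among the measured compounds shown here, no step between two measured compounds isolates this change, as compound 1 and compound 2 differ in more than one place, so the expectation rests on the two values alone. A small step toward a lower number is expected for compound 3, of size a 1.7-fold lower number from compound 2 to compound 3 (0.22 log units; within the scatter), though it may not exceed the scatter. In this assay compound 3 is estimated to give 12000 nM, within a range from 5000 nM to 30000 nM.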

Compound 3, half-maximal inhibitory concentration: 7900 nM
For compound 3 the middle estimate is 1.5-fold (0.18 log units) above the measured one; the range from low to high includes it.
By their numbers in this assay, from the lowest: compounds 3 and 1 (each within the scatter of the next); then compound 2.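

In this assay, the methyl to ethyl change, with the methoxy kept in both compounds, gives a 2.5-fold lower number from compound 2 to compound 3 (0.40 log units; beyond the scatter), so this place on a saturated chain carbon bound to an amine nitrogen responds to methyl in place of hydrogen by more than the scatter. The other single change, methoxy in place of hydrogen on an aromatic carbon, gives a 1.0-fold lower number from compound 1 to compound 3 (0.02 log units; within the scatter), so with ethyl present this change shows no difference beyond the scatter. Nothing at hand bears on the reason for either result. From the compounds shown here alone, whether a propyl or a longer chain in the ethyl place would carry the step further remains open. So does whether methoxy on the aromatic carbon would also stay within the scatter alongside methyl rather than ethyl, and how a chloro group there would read.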